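Cyclopropyloxy to 1-Methylethenyl: Expected Maximal Response

The source may hold more compounds than are shown below. What is called first, only, known or untested is meant among the compounds shown, and "the series" means these compounds.

compound 1 `CC(C)Oc1ccccc1OC(C)C1=NCCN1`: 0.5
compound 2 `CC(Oc1ccccc1OC1CC1)C1=NCCN1`: 0.6

In an assay on CHO cells with Alpha-2B adrenergic receptor (Homo sapiens) as the target (on this read-out lower numbers stand for smaller maximal responses and higher numbers for larger maximal responses), compound 2 gives 0.6, while compound 1 gives 0.5; the two numbers lie within the scatter of each other. Compound 3 `C=C(C)c1ccccc1OC(C)C1=NCCN1` differs from compound 2 by 1-methylethenyl in place of cyclopropyloxy on an aromatic carbon. Within the data shown here, the only measured step, a number 0.10 higher from compound 1 to compound 2 (within the scatter), exchanged one group on that oxygen for another and stayed within the scatter; it does not cover loss of the oxygen itself, so no measured step bears directly on the change. Compound 3 is therefore expected to show a step of about a number 0.050 lower from compound 2 to compound 3 (within the scatter), no larger than the scatter. The estimate for compound 3 is 0.55, in a range from 0.35 to 0.75.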

Compound 3, intrinsic activity: the largest response reached, as a fraction of the reference agonist's: 0.4
The estimate for compound 3 lay 0.15 above the measured number; the range from low to high includes it.
By their numbers in this assay, from the lowest: compounds 3, 1 and 2 (each within the scatter of the next, the first and the last beyond it).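

Among these compounds, at this aromatic carbon, in this assay, the exchange of cyclopropyloxy for 1-methylethenyl gave the only step so far that lies beyond the scatter (a number 0.20 lower from compound 2 to compound 3 (beyond the scatter)). The exchange of isopropoxy for 1-methylethenyl did not (a number 0.10 lower from compound 1 to compound 3 (within the scatter)), so losing the oxygen at this place does not by itself carry the maximal response beyond the scatter. Nothing measured here accounts for the difference between these two exchanges.

As far as these compounds go, whether an amine or a longer chain on this aromatic carbon would give a maximal response nearer compound 2 or compound 3 remains open.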